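Bromo in place of hydrogen on compound 3

The compounds below may be only part of what the source reports. "The series", "measured", "known", "first", "only" and "open" are said of these compounds alone.

In a functional assay on HepG2 cells (Homo sapiens) for antiproliferative activity, read by fluorescence and resazurin assay, with a stated time of 48 h (on this read-out higher numbers stand for weaker inhibition and lower numbers for stronger inhibition), compound 1 (`CCOc1ccc(NC(=O)c2cc3cc(Br)ccc3oc2=O)cc1`) gives 37000 nM and compound 2 (`O=C(N/N=C/c1cccnc1)c1cc2ccc(O)cc2oc1=O`) gives 18400 nM as its value. Compound 3 (`CCOc1ccc2nc(Cl)c(/C=N/NC(=O)c3cc4ccccc4oc3=O)cc2c1`) gives 33100 nM in the same read-out, which lies within the scatter of both other values, so these three numbers carry no order.

Compound 4 (`CCOc1ccc2nc(Cl)c(/C=N/NC(=O)c3cc4cc(Br)ccc4oc3=O)cc2c1`) differs from compound 3 in one place: bromo in place of hydrogen on an aromatic carbon. That carbon belongs to a six-membered aromatic ring of carbon only, part of a fused system of two rings. For the measured compounds named here, no measured pair differs in one place, so the data give no direct size for this change.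

Compound 1 also carries a bromo, and its value (37000 nM) lies within the scatter of compound 3 (33100 nM). The two differ elsewhere as well, so this is weak support at best. In this assay no step beyond the scatter is expected, in either direction. The estimated step is a 1.2-fold lower number from compound 3 to compound 4 (0.07 log units; within the scatter) as an expectation only. For compound 4 the estimated value is 28000 nM with an expected range of 10000 nM to 70000 nM in this read-out.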

Compound 4, half-maximal inhibitory concentration: 29000 nM
The estimate for compound 4 lay 1.0-fold (0.02 log units) below the measured number; measured number inside the range.
By their numbers in this assay, from the lowest: compounds 2, 4, 3 and 1 (each within the scatter of the next).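

In this assay the pair gives the series its first direct size for this change: a 1.1-fold lower number from compound 3 to compound 4 (0.06 log units; within the scatter), for bromo in place of hydrogen on an aromatic carbon of the six-membered aromatic ring of carbon only. The read-out therefore does not separate the two compounds, and this position, meta to a fused ring and para to a fused ring, carries the single bromine atom with no step beyond the scatter in this pair. This is one pair on one shared core, so it gives a size for this change here and no rule for bromo elsewhere, and nothing available explains the result or ties it to any property of the group.

Whether this position stays as indifferent to a larger or more functional group, such as an amine, a carboxylic acid or a longer alkoxy chain, remains open, since bromo is the only replacement for hydrogen shown there. For the compounds shown here, also open is whether any single change on the shared core can produce a step beyond the scatter in this assay, since the one step available stays within it.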